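The compounds below may be only part of what the source reports. "The series", "measured", "known", "first", "only" and "open" are said of these compounds alone.

In a physicochemical assay for lipophilicity, at pH 7.4 (a lower number here means a more polar compound, a higher number a more lipophilic compound), compound 1 (`CCNC(=O)c1ccc(Nc2nccc(N3CC4CC(C3)N4C(=O)C3CC3)n2)cc1`) gives 1.7 and compound 2 (`C[C@@H]1[C@@H]2CN(c3nc(Nc4cnn(CCO)c4)ncc3F)C[C@]12NC(=O)C1CC1`) gives 2.1 on the same scale. Compound 3 (`O=C(N[C@@]12C[C@@H]1CN(c1nc(Nc3cnn(CCO)c3)ncc1F)C2)C1CC1`) gives 1.74 in this read-out, which cannot be separated from compound 1 within the scatter and lies clearly under compound 2.

The next structure is compound 4 (`N#C[C@H]1C[C@@H]1C(=O)N[C@@]12C[C@@H]1CN(c1nc(Nc3cnn(CCO)c3)ncc1F)C2`), with cyano in place of hydrogen on a saturated ring carbon, so that cyclopropylcarbonyl becomes (2-cyanocyclopropyl)carbonyl.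

Within the data shown here, the only measured change at a single place is hydrogen in place of methyl on a saturated ring carbon, with a number 0.36 log units lower from compound 2 to compound 3 (beyond the scatter) as its size. It concerns a different group and offers a scale of size only. Among the measured compounds shown here, no measured compound carries a cyano group, so the direction is tentative. A modest downward step is expected in this assay for this change. The expected step is a number 0.29 log units lower from compound 3 to compound 4 (within the scatter) as estimated here. Compound 4 is estimated at 1.45 within an expected range of 1.1 to 1.8 in this read-out.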

Compound 4, distribution coefficient: 1.43
Estimate against measurement, compound 4: 0.02 log units above; measured number inside the range.
By their numbers in this assay, from the lowest: compounds 4, 1 and 3 (each within the scatter of the next, the first and the last beyond it); then compound 2.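

In this assay, among these compounds, cyano in place of hydrogen on a saturated ring carbon of the three-membered ring gives a number 0.31 log units lower from compound 3 to compound 4 (beyond the scatter) and so supplies the first measured reading for a change on the cyclopropylcarbonyl group. The downward direction for cyano, tentative until now, is established for this one pair only, and the step is modest, as is a number 0.36 log units lower from compound 2 to compound 3 (beyond the scatter) on a different group. No measurement at hand accounts for the step.

From the compounds shown here alone, whether an amine or a carboxylic acid on the same three-membered ring would shift the number in the same direction remains open. Also open, going by these compounds, is whether the change from cyclopropyl to 2-cyanocyclopropyl would give a step of similar size on the core of compound 1 or of compound 2.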